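This account rests on a few compounds, and the source may have more. Where it says the series, first, only, none or still open, it means among the compounds named here.

Three compounds with a shared core, differing at a saturated chain carbon bound to an oxygen on an aromatic ring, have been read in an ADME assay on KB cells (Homo sapiens) for cytotoxicity; on this read-out higher numbers stand for an effect only at larger amounts of compound and lower numbers for an effect already at smaller amounts. Compound 1 `CCOc1c(OC)c(OC)cc2c1C(=O)[C@]1(OC)C=C[C@H]2N(C(=O)OCC(C)C)N1C(=O)OCC(C)C` gives > 300 ug/mL, and this value is a limit of the assay. Compound 2 `COc1cc2c(c(OCc3ccccc3)c1OC)C(=O)[C@]1(OC)C=C[C@H]2N(C(=O)OCC(C)C)N1C(=O)OCC(C)C` gives 94 ug/mL. Among the measured compounds shown here, compound 3 `CCCCOc1c(OC)c(OC)cc2c1C(=O)[C@]1(OC)C=C[C@H]2N(C(=O)OCC(C)C)N1C(=O)OCC(C)C` gives 22.1 ug/mL, the lowest of the numbers so far.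

Compound 4 `COc1cc2c(c(OCc3ccccc3F)c1OC)C(=O)[C@]1(OC)C=C[C@H]2N(C(=O)OCC(C)C)N1C(=O)OCC(C)C` is the next to be read, and it differs from compound 3 as follows: 2-fluorophenyl in place of propyl on a saturated chain carbon bound to an oxygen on an aromatic ring. Put simply, 2-fluorophenyl stands in place of propyl, or butoxy becomes (2-fluorobenzyl)oxy.

Two steps set the background: an at least 3.1-fold lower number from compound 1 to compound 2 (0.50 log units; beyond the scatter) and an at least 13-fold lower number from compound 1 to compound 3 (1.13 log units; beyond the scatter). The closest guide is a 4.3-fold lower number from compound 2 to compound 3 (0.63 log units; beyond the scatter), which exchanges phenyl and propyl at this same place. Read in reverse, it points upward for compound 4. For the measured compounds named here, no measured step covers the fluorine itself, so a modest rise in this assay is expected. The expected step is a 3.4-fold higher number from compound 3 to compound 4 (0.53 log units; beyond the scatter). For compound 4 the estimate is 75 ug/mL, with an expected range from 25 ug/mL to 220 ug/mL.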

Compound 4, concentration for half-maximal effect: 109 ug/mL
Compound 4: middle estimate off by 1.5-fold (0.16 log units), on the low side; the range from low to high includes it.
By their numbers in this assay, from the lowest: compound 3; then compounds 2 and 4 (each within the scatter of the next). At a limit, above all of these: compound 1.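

In this assay, the fluoro group on the aromatic ring gives a difference that stays within the usual scatter, a 1.2-fold higher number from compound 2 to compound 4 (0.06 log units; within the scatter), so compound 2 and compound 4 cannot be told apart at this position. The gap between the butoxy group and a benzyl-type ether therefore also holds with the fluorine present, a 4.9-fold higher number from compound 3 to compound 4 (0.69 log units; beyond the scatter), and compound 3 keeps the lowest number of the four. The value of compound 1 is a limit, which leaves an at least 2.7-fold lower number from compound 1 to compound 4 (0.43 log units; beyond the scatter) as a bound only: the limit of > 300 ug/mL in this assay, at which 1 of the 4 values shown sits.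

As far as these compounds go, whether a chloro or a methoxy group on the phenyl ring would shift the number beyond the scatter remains open. So does whether a chain longer than butyl, such as hexyl, would go lower than compound 3 in this assay.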